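The source may report more compounds than this note shows. Statements on the series, on what has been measured and on what is new or still open speak of the compounds shown alone.

Measured so far:
Compound 1 `CN(Cc1ccc2nccn2c1)c1nnc(-c2ccccc2)o1` gives 2.4 in a physicochemical assay for lipophilicity, at pH 7.4; on this read-out lower numbers stand for lower lipophilicity and higher numbers for higher lipophilicity.
Compound 2 `CN(Cc1ccc2nccn2c1)c1nnc(-c2ccc(-c3ccccc3)cc2)o1` gives 3.9 in this assay.

Among the measured compounds shown here, compound 2 stands highest of the two numbers; the only known step, a number 1.50 log units higher from compound 1 to compound 2 (beyond the scatter), is large. Compound 3 `COc1ccccc1-c1ccc(-c2nnc(N(C)Cc3ccc4nccn4c3)o2)cc1` differs from compound 2 by methoxy in place of hydrogen on an aromatic carbon. For the measured compounds named here, no measured step involves a methoxy group, so that one phenyl step gives no direct guide here, and a change of this kind is expected to stay within the scatter. Compound 3 is therefore estimated at 3.9, in a range from 3.5 to 4.3, which is an expected step of no change at the digits printed from compound 2 to compound 3 (within the scatter).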

Compound 3, distribution coefficient: 4.1
Compound 3: middle estimate off by 0.20 log units, on the low side; the range from low to high includes it.
By their numbers in this assay, from the lowest: compound 1; then compounds 2 and 3 (each within the scatter of the next).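

In this assay, methoxy on an aromatic carbon ortho to a large group gives a step that stays within the scatter: a number 0.20 log units higher from compound 2 to compound 3 (within the scatter). With 2-methoxyphenyl in place of hydrogen on an aromatic carbon, the large step seen with phenyl remains, a number 1.70 log units higher from compound 1 to compound 3 (beyond the scatter), so this position carries methoxy without a readable difference from compound 2. Nothing at hand accounts for this result.

Still open, going by these compounds, is whether an amine or a carboxylic acid on that same carbon would also stay within the scatter of compound 2.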